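Methylsulfonyl pyridazine replacing cyanopyrazine on the shared core

The compounds below may be only part of what the source reports. "The series", "measured", "known", "first", "only" and "open" are said of these compounds alone.

Compound 1 `CC(C)(C)OC(=O)N1CCC(O[C@H]2CC[C@H](Oc3ccc(C#N)cc3)CC2)CC1` gives 45 nM in a functional assay on isolated protein for agonist activity at Glucose-dependent insulinotropic receptor (Rattus norvegicus), read by HTRF and cAMP accumulation; on this read-out lower numbers stand for an effect already at smaller amounts and higher numbers for an effect only at larger amounts of compound; compound 2 `CC(C)(C)OC(=O)N1CCC(O[C@H]2CC[C@H](Oc3cnc(S(C)(=O)=O)cn3)CC2)CC1` gives 64 nM in this assay; compound 3 `CC(C)(C)OC(=O)N1CCC(O[C@H]2CC[C@H](Oc3cnc(C#N)cn3)CC2)CC1` gives 28.4 nM in this assay.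

Compound 3 has the lowest number of the three, though its gap to compound 1 stays within the scatter, and only a 2.3-fold lower number from compound 2 to compound 3 (0.35 log units; beyond the scatter) exceeds it. Compound 4 `CC(C)(C)OC(=O)N1CCC(O[C@H]2CC[C@H](Oc3ccc(S(C)(=O)=O)nn3)CC2)CC1` differs from compound 3 by 6-(methylsulfonyl)pyridazin-3-yl in place of 5-cyanopyrazin-2-yl on an oxygen on a saturated carbon. The step that bears most directly on this change is a 2.3-fold lower number from compound 2 to compound 3 (0.35 log units; beyond the scatter), in which cyano replaced methylsulfonyl; the change to compound 4 reverses that swap while also exchanging the ring. Among the measured compounds shown here, the ring exchange has no measured counterpart, so the reversal of the sulfonyl step guides the expectation, with compound 2 as the closer analogue. Compound 4 is therefore expected to give a modestly higher number, a 2.3-fold higher number from compound 3 to compound 4 (0.36 log units; beyond the scatter), and its value in this assay is estimated at 65 nM, within 30 nM to 140 nM.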

Compound 4, half-maximal effective concentration: 1160 nM
Compound 4: the middle estimate sits 18-fold (1.25 log units) below what was measured, and the stated range ends below it.
By their numbers in this assay, from the lowest: compounds 3, 1 and 2 (each within the scatter of the next, the first and the last beyond it); then compound 4.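

In this assay, the group on this oxygen proves far less forgiving than the first three compounds suggested: 6-(methylsulfonyl)pyridazin-3-yl brings a 41-fold higher number from compound 3 to compound 4 (1.61 log units; beyond the scatter) and a 26-fold higher number from compound 1 to compound 4 (1.41 log units; beyond the scatter). With methylsulfonyl kept, the ring exchange alone gives an 18-fold higher number from compound 2 to compound 4 (1.26 log units; beyond the scatter), so the change of ring, rather than the loss of cyano, accounts for most of the rise in the number. Nothing available explains why these two rings differ so sharply.

On these data alone, whether the same pyridazin-3-yl ring would behave likewise with cyano, an amine or a carboxylic acid in place of methylsulfonyl stays open.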